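Series notes: step from compound 2 to compound 4

The source may report more compounds than this note shows. Statements on the series, on what has been measured and on what is new or still open speak of the compounds shown alone.

Compound 1 `CCOC(=O)C1=C(C)NC(C)=C(C(=O)OCC)C1c1c(-c2ccccc2F)nc2sccn12`: 980 nM
Compound 2 `CCOC(=O)C1=C(C)NC(C)=C(C(=O)OCC)C1c1c(-c2ccc(F)cc2)nc2sccn12`: 1650 nM
Compound 3 `CCOC(=O)C1=C(C)NC(C)=C(C(=O)OCC)C1c1c(-c2ccc(F)cc2)nc2sc(Cl)cn12`: 1730 nM

In an ADME assay on Right cardiac atrium (Cavia porcellus) (on this read-out lower numbers stand for an effect already at smaller amounts and higher numbers for an effect only at larger amounts of compound), compound 2 lies within the scatter of both other compounds: the step from compound 1 to compound 2 is a 1.7-fold higher number from compound 1 to compound 2 (0.23 log units; within the scatter), and the step from compound 2 to compound 3 is a 1.0-fold higher number from compound 2 to compound 3 (0.02 log units; within the scatter). Compound 4 `CCOC(=O)C1=C(C)NC(C)=C(C(=O)OCC)C1c1c(-c2ccc(F)c(F)c2)nc2sccn12` differs from compound 2 by fluoro in place of hydrogen on an aromatic carbon, read one bond further out as 4-fluorophenyl to 3,4-difluorophenyl. Within the data shown here, no measured step adds a fluoro; the two known steps, a moved fluoro and an added chloro, both stayed within the scatter, so no step beyond the scatter is expected in this assay. Compound 4 is expected at 1500 nM (range 600 nM to 4000 nM), which corresponds to an expected step of a 1.1-fold lower number from compound 2 to compound 4 (0.04 log units; within the scatter).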

Compound 4, half-maximal effective concentration: 100 nM
For compound 4 the middle estimate is 15-fold (1.18 log units) above the measured one, outside the stated range (below it).
By their numbers in this assay, from the lowest: compound 4; then compounds 1, 2 and 3 (each within the scatter of the next).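

In this assay, fluoro in place of hydrogen on the carbon ortho to a fluoro group and meta to a large group gives a 17-fold lower number from compound 2 to compound 4 (1.22 log units; beyond the scatter), so this position responds strongly, unlike the earlier moved-fluoro and added-chloro steps, which stayed within the scatter. The 3,4-difluorophenyl group also separates from the 2-fluorophenyl group, with a 9.8-fold lower number from compound 1 to compound 4 (0.99 log units; beyond the scatter), so neither single-fluoro placement shown matches it. Nothing available explains this shift. Going by these compounds, whether chloro, methoxy or a nitrile at this position gives a step of similar size remains open. Also open, on these data alone, is whether the 3,4-difluorophenyl step persists with the chloro of compound 3 present.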